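The source may hold more compounds than are shown below. What is called first, only, known or untested is meant among the compounds shown, and "the series" means these compounds.

Measured so far:
- compound 1 `NC(=O)Cc1ccccc1-c1ccc(COC2CC[C@H](N3CCCCCC3)[C@H]2OC/C=C\CCC(=O)O)cc1`: 7.94 nM
- compound 2 `CC(=O)NCc1ccc(-c2ccc(COC3CC[C@H](N4CCCCCC4)[C@H]3OC/C=C\CCC(=O)O)cc2)cc1`: 2.51 nM

In a functional assay on blood for antagonist activity at thromboxane A2 receptor (Homo sapiens) (a higher number here means weaker binding, a lower number tighter binding), compound 1 gives 7.94 nM, the highest of the two numbers; compound 2 gives 2.51 nM, a step of a 3.2-fold lower number from compound 1 to compound 2 (0.50 log units; beyond the scatter). Compound 3 `O=C(O)CC/C=C\CO[C@H]1C(OCc2ccc(-c3ccccc3CO)cc2)CC[C@@H]1N1CCCCCC1` differs from compound 1 by hydroxy in place of carbamoyl on a saturated chain carbon bound to an aromatic carbon. No measured step touches this position; the one step shown reshapes a different part of the aryl substituent, so it gives no direct guide. The change is therefore expected to stay within scatter, with an estimated step of a 1.0-fold higher number from compound 1 to compound 3 (0.00 log units; within the scatter). Compound 3 is estimated at 8 nM, in a range of 3 nM to 25 nM.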

Compound 3, dissociation constant: 3.16 nM
Beside the measured number, compound 3's estimate is 2.5-fold (0.40 log units) above it; measured number inside the range.
By their numbers in this assay, from the lowest: compounds 2 and 3 (each within the scatter of the next); then compound 1.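

Hydroxy in place of carbamoyl on a saturated chain carbon bound to an aromatic carbon gives a 2.5-fold lower number from compound 1 to compound 3 (0.40 log units; beyond the scatter) in this assay, so carbamoyl is not needed at this position for a low number. 2-(Hydroxymethyl)phenyl in place of 4-(acetamidomethyl)phenyl gives a 1.3-fold higher number from compound 2 to compound 3 (0.10 log units; within the scatter), which leaves these two substituents unseparated in this assay. Nothing available explains either step.

Open, going by these compounds, is how an amine or a methoxy group in place of hydroxy at this position would read. Also open, on these data alone, is whether a longer chain carrying the hydroxy would hold the number of compound 3.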